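From 4-methoxybutoxy to (but-3-en-1-yl)oxy at the assay limit

A few compounds are considered here, and "the series" means these few. Any claim that something is new, unique, unknown or untested is made for them only; others in the source may bear on it.

Of the compounds shown here, three sharing one core have been tested in an ADME assay on RAW264.7 cells (Mus musculus) for cytotoxicity, read by MTT assay, with a stated time of 24 h, in the absence of a further agent (a higher number here means a weaker inhibitor, a lower number a stronger inhibitor), and none has yet given a real number. Compound 1 `CCOc1ccc(C(O)C2OC(=O)c3c(OC)cc(OC)cc32)cc1` reads > 40000 nM as a limit of the assay. Compound 2 `CCCCOc1ccc(C(O)C2OC(=O)c3c(OC)cc(OC)cc32)cc1` reads > 40000 nM as a limit too. Compound 3 `COCCCCOc1ccc(C(O)C2OC(=O)c3c(OC)cc(OC)cc32)cc1` reads > 40000 nM as a limit as well. Compound 3 therefore stands with the others at the limit of > 40000 nM in this assay, at which 3 of the 3 values shown sit, and no rank among the three can be read.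

Compound 4 `C=CCCOc1ccc(C(O)C2OC(=O)c3c(OC)cc(OC)cc32)cc1` differs from compound 3 in one place, with vinyl in place of 2-methoxyethyl on a saturated chain carbon, two bonds along the chain from an oxygen on an aromatic ring. Three measured steps change this same chain: a step that the two limits leave unreadable from compound 1 to compound 2 and a step that the two limits leave unreadable from compound 1 to compound 3 and a step that the two limits leave unreadable from compound 2 to compound 3 and none of them has a size that can be read. All three chains tested so far sit at the same limit, so no step beyond the scatter is expected in this assay and no direction can be given. The expected step is a step that the limit leaves unreadable from compound 3 to compound 4 with the chain change alone to account for it. The expected value for compound 4 is 50000 nM within a range of 30000 nM to 100000 nM and the assay may well report only a limit again.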

Compound 4, half-maximal inhibitory concentration: > 40000 nM
Compound 4: a limit, no number; the forecaster's own chance of this, stated with the estimate: 85%; the middle value is on the limit's open side.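

In this assay compound 4 gives > 40000 nM, which is a limit and not a number. Its steps from compound 1, compound 2 and compound 3 therefore cannot be read: the limit of > 40000 nM in this assay, at which 4 of the 4 values shown sit.

The compounds shown leave open whether any chain on the shared core would give a real number in this assay, and how far the chains differ.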